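Extending the Nitrogen Substituent in a Reductase Inhibitor Pair

The compounds below may be only part of what the source reports. "The series", "measured", "known", "first", "only" and "open" are said of these compounds alone.

Measured compounds:
compound 1, `C/C(=C\C(=O)Nc1ccccc1OCCCC(=O)O)c1ccc2c(ccn2C)c1`, 780 nM
compound 2, `CC(C)=CCn1ccc2cc(/C(C)=C/C(=O)Nc3ccccc3OCCCC(=O)O)ccc21`, 120 nM

In an assay on Prostate gland for inhibition of steroid 5-alpha-reductase (Rattus norvegicus) (a lower number here means a stronger inhibitor, a higher number a weaker inhibitor), compound 2 gives 120 nM, the lowest of the two numbers; compound 1 gives 780 nM. Going by the values given here, the only step in hand, a 6.5-fold lower number from compound 1 to compound 2 (0.81 log units; beyond the scatter), shows the number falling when a group is added at that nitrogen. Compound 3, `CCCC(c1ccccc1)n1ccc2cc(/C(C)=C/C(=O)Nc3ccccc3OCCCC(=O)O)ccc21`, carries 1-phenylbutyl in place of 3-methylbut-2-en-1-yl on an aromatic nitrogen. That one step bears on the new change, since it also enlarges what sits on the nitrogen, so a modest further fall is expected, a 2.0-fold lower number from compound 2 to compound 3 (0.30 log units; within the scatter). Compound 3 is therefore estimated at 60 nM, with a range from 15 nM to 250 nM.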

Compound 3, half-maximal inhibitory concentration: 9.1 nM
Compound 3: the middle estimate sits 6.6-fold (0.82 log units) above what was measured, outside the stated range (below it).
By their numbers in this assay, from the lowest: compound 3; then compound 2; then compound 1.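

Replacing 3-methylbut-2-en-1-yl with 1-phenylbutyl on the aromatic nitrogen gives a 13-fold lower number from compound 2 to compound 3 (1.12 log units; beyond the scatter) in this assay, so this position accepts a group carrying a six-membered aromatic ring, and the number falls further. Taken from methyl, the change amounts to an 86-fold lower number from compound 1 to compound 3 (1.93 log units; beyond the scatter), and across these compounds the number falls as the group on the nitrogen grows. Nothing available explains this fall.

The compounds shown leave open whether the phenyl ring or the propyl part of 1-phenylbutyl matters more. A plain benzyl group or an unbranched butyl chain would separate the two.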